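The compounds below may be only part of what the source reports. "The series", "measured", "known", "first", "only" and "open" are said of these compounds alone.

Working notes on the series. In a functional assay on HUVEC cells (Homo sapiens) (on this read-out higher numbers stand for an effect only at larger amounts of compound and lower numbers for an effect already at smaller amounts), compound 1 `Cc1c(O)c(C)c2c(c1O)C(=O)CC(c1ccccc1O)O2` gives > 20000 nM, and this value is a limit. Compound 2 `Cc1c(O)c(C)c2c(c1O)C(=O)CC(c1ccccc1[N+](=O)[O-])O2` gives > 5000 nM, which is also a limit. No numerical value is therefore available for either compound in this assay.

The next change leads to compound 3 `Cc1c(O)c(C)c2c(c1O)C(=O)CC(c1ccco1)O2`, with furan-2-yl in place of 2-hydroxyphenyl on a saturated ring carbon, next to the ring oxygen: furan-2-yl in place of 2-hydroxyphenyl on a saturated ring carbon.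

Within the data shown here, the one measured step, nitro in place of hydroxy on an aromatic carbon, is a step that the two limits leave unreadable from compound 1 to compound 2, so it provides no size to carry over and does not touch this ring swap directly. No step beyond the scatter is expected in this assay, and no direction can be assigned. The expected change is a number no higher from compound 1 to compound 3 (the limit leaves the size open). The estimate for compound 3 is 20000 nM, with an expected range of 6000 nM to 50000 nM.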

Compound 3, half-maximal effective concentration: > 20000 nM
Compound 3: no number, only a limit (the forecaster's own chance of this, stated with the estimate: 70%); the middle value sits exactly at the limit.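

In this assay compound 1 and compound 3 both give only limits, so no step can be read between them. The compounds shown leave open whether furan-2-yl in place of 2-hydroxyphenyl changes the read-out at all, since none of the three has a numerical value.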